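Sulfonyl aryl replacement: from compound 1 to compound 3

The source may report more compounds than this note shows. Statements on the series, on what has been measured and on what is new or still open speak of the compounds shown alone.

Measured so far:
compound 1, `O=C(NCc1ccc(CNS(=O)(=O)c2ccc([N+](=O)[O-])cc2)cc1)c1ccc(CNc2ncccn2)cc1`: 1000 nM
compound 2, `O=C(NCc1ccc(CNS(=O)(=O)c2cccc(C(F)(F)F)c2)cc1)c1ccc(CNc2ncccn2)cc1`: 1000 nM

In an assay on MDA-MB-231 cells for binding affinity to C-X-C chemokine receptor type 4 (Homo sapiens), read by microscopy, with stated times of 10 min and 30 min (on this read-out lower numbers stand for an effect already at smaller amounts and higher numbers for an effect only at larger amounts of compound), compound 1 gives 1000 nM, and compound 2 gives 1000 nM, so compound 1 stands level with compound 2 within the scatter. Going by the values given here, the single measured step, no change at the digits printed from compound 1 to compound 2 (within the scatter), is the only one that bears on the present change. Compound 3, `O=C(NCc1ccc(CNS(=O)(=O)c2cccc3ccccc23)cc1)c1ccc(CNc2ncccn2)cc1`, differs from compound 1 as follows: naphthalen-1-yl in place of 4-nitrophenyl on a sulfonyl sulfur. Among the compounds with values here, since the one known swap on the sulfonyl sulfur moved nothing in this assay , no step beyond the scatter is expected here either, no change at the digits printed from compound 1 to compound 3 (within the scatter). Compound 3 is estimated at 1000 nM, within 400 nM to 2500 nM.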

Compound 3, effective concentration (reported as EC, without a stated level of effect): 1000 nM
Estimate against measurement, compound 3: no gap at the digits printed; measured number inside the range.
By their numbers in this assay, from the lowest: compounds 1, 2 and 3 (each within the scatter of the next).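

In this assay, the sulfonyl sulfur now carries naphthalen-1-yl, with no hydrogen-bond acceptors, and the reading shows no change at the digits printed from compound 1 to compound 3 (within the scatter) and no change at the digits printed from compound 2 to compound 3 (within the scatter). The hydrogen-bond acceptors of 4-nitrophenyl can therefore be lost at this position, and a second six-membered aromatic ring gained, without a step beyond the scatter. No data here explain why these aryl groups read alike.

Going by these compounds, whether an amine or a carboxylic acid on the aryl group would move the reading stays open. So does the effect of a longer alkyl chain in place of the aryl group on the sulfonyl sulfur.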